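The compounds below may be only part of what the source reports. "The series", "measured", "known", "first", "only" and "open" are said of these compounds alone.

In a functional assay on U-87MG ATCC cells for antiproliferative activity against U-87 MG (Homo sapiens), read by MTT assay, with a stated time of 48 h (on this read-out lower numbers stand for stronger inhibition and higher numbers for weaker inhibition), compound 1 (`COc1ccc(-c2nc(C)c(C(=O)CSc3nc(-c4ccc(Cl)cc4)c(C#N)c(=O)[nH]3)s2)cc1`) gives 45900 nM, and compound 2 (`Cc1nc(-c2ccccc2)sc1C(=O)CSc1nc(-c2ccc(Cl)cc2)c(C#N)c(=O)[nH]1`) gives 43400 nM, so the two stand level within the scatter. Compound 3 (`COc1ccc(-c2nc(C)c(C(=O)CSc3nc(-c4cccc(Cl)c4)c(C#N)c(=O)[nH]3)s2)cc1`) has 3-chlorophenyl in place of 4-chlorophenyl on an aromatic carbon. Among the measured compounds shown here, no measured step touches the chlorophenyl group. The only one, a 1.1-fold lower number from compound 1 to compound 2 (0.02 log units; within the scatter), concerns the methoxy group and lies within the scatter. No change beyond the scatter is therefore expected in this assay, in either direction. The expected step is a 1.1-fold lower number from compound 1 to compound 3 (0.04 log units; within the scatter). For compound 3 the estimated value is 42000 nM, with an expected range of 20000 nM to 90000 nM.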

Compound 3, half-maximal inhibitory concentration: 78900 nM
Compound 3: the middle estimate sits 1.9-fold (0.27 log units) below what was measured, within the range that was stated.
By their numbers in this assay, from the lowest: compounds 2, 1 and 3 (each within the scatter of the next).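

In this assay, among the compounds shown here, the swap of 4-chlorophenyl for 3-chlorophenyl gives the first measured step at this group, a 1.7-fold higher number from compound 1 to compound 3 (0.24 log units; within the scatter). Moving the chlorine thus leaves compound 3 level with compound 1, so this change, like the earlier methoxy step, does not separate the compounds beyond the scatter. Nothing available bears on the reason for this small difference. The compounds shown leave open whether putting an amine or a carboxylic acid in place of the chlorine, rather than moving it, would shift the number beyond the scatter.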